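Amide aryl swap on the acetamido core

This account rests on a few compounds, and the source may have more. Where it says the series, first, only, none or still open, it means among the compounds named here.

Two compounds of the series are measured in a functional assay on SK-MEL-2 cells (Homo sapiens) for antiproliferative activity, read by sulforhodamine B assay, with a stated time of 48 h; on this read-out lower numbers stand for stronger inhibition and higher numbers for weaker inhibition. Compound 1 `Nc1cccc2c(-c3cccc(NC(=O)c4ccc(Cl)c(C(F)(F)F)c4)c3)ccnc12` gives 3500 nM. Compound 2 `COc1ccc(C(=O)Nc2cccc(-c3ccnc4c(NC(C)=O)cccc34)c2)cc1OC` gives 9400 nM, the highest of the two numbers; its nearest neighbour is compound 1, and the gap between them lies beyond the usual scatter. Among the measured compounds shown here, no pair of measured compounds differs in one place only, so no single step is counted.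

Compound 3 `CC(=O)Nc1cccc2c(-c3cccc(NC(=O)c4ccc(Cl)c(C(F)(F)F)c4)c3)ccnc12` is not yet measured. It keeps the core of compound 2 and changes the acyl group: 4-chloro-3-(trifluoromethyl)phenyl in place of 3,4-dimethoxyphenyl on a carbonyl carbon. Compound 1 carries this same 4-chloro-3-(trifluoromethyl)phenyl group on a different core.

In this assay compound 3 is expected to land lower than compound 2, with a step of about a 2.4-fold lower number from compound 2 to compound 3 (0.37 log units; beyond the scatter), because compound 1 with the same acyl group gives 3500 nM. The estimate for compound 3 is 4000 nM, within a range from 1500 nM to 11000 nM.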

Compound 3, half-maximal inhibitory concentration: 3400 nM
Beside the measured number, compound 3's estimate is 1.2-fold (0.07 log units) above it; the measured number falls inside the stated range.
By their numbers in this assay, from the lowest: compounds 3 and 1 (each within the scatter of the next); then compound 2.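

In this assay, among the compounds shown here, with the shared core held, 4-chloro-3-(trifluoromethyl)phenyl in place of 3,4-dimethoxyphenyl on a carbonyl carbon gives a 2.8-fold lower number from compound 2 to compound 3 (0.44 log units; beyond the scatter), the first single-place reading at this position. With that aryl group held, acetyl in place of hydrogen on a nitrogen on an aromatic ring gives a 1.0-fold lower number from compound 1 to compound 3 (0.01 log units; within the scatter), so this assay does not separate the two compounds on that nitrogen. Nothing available accounts for either step.

The compounds shown do not tell whether a lone chlorine or a lone trifluoromethyl on the phenyl ring would give the same step, or how a pyridine ring would read at this position. From the compounds shown here alone, it also stays open whether a propanoyl group or a methanesulfonyl group on that nitrogen would read like acetyl, and whether the acetyl reading would hold with 3,4-dimethoxyphenyl on the carbonyl carbon.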